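The source may report more compounds than this note shows. Statements on the series, on what has been measured and on what is new or still open speak of the compounds shown alone.

Within the data shown here, in an ADME assay on J774.A1 cells (Mus musculus) for inhibition, read by MTT assay, with a stated time of 72 h (on this read-out lower numbers stand for an effect already at smaller amounts and higher numbers for an effect only at larger amounts of compound), compound 2 `COc1ccc(CNc2nc(NCc3ccccc3)nc3ccccc23)cc1` gives 5200 nM, the highest of the two numbers so far, and compound 1 `Cc1ccc(CNc2nc(NCc3ccccc3)nc3ccccc23)cc1` gives 2100 nM. Compound 3 `Clc1ccc(CNc2nc(NCc3ccccc3)nc3ccccc23)cc1` differs from compound 2 at one place: chloro in place of methoxy on an aromatic carbon, with chloro in place of methoxy on an aromatic carbon, para to a large group. Among the measured compounds shown here, the only measured step at this place, methoxy in place of methyl, is modest: a 2.5-fold higher number from compound 1 to compound 2 (0.39 log units; beyond the scatter). One step is thin evidence, but removing methoxy is expected to give a similarly modest fall, an estimated 2.0-fold lower number from compound 2 to compound 3 (0.30 log units; within the scatter). The expected value for compound 3 is 2600 nM, within an estimated range of 1100 nM to 6000 nM.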

Compound 3, half-maximal effective concentration: 4600 nM
Compound 3: the middle estimate sits 1.8-fold (0.25 log units) below what was measured; low and high end bracket the measured number.
By their numbers in this assay, from the lowest: compound 1; then compounds 3 and 2 (each within the scatter of the next).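

In this assay, chloro in place of methoxy gives a 1.1-fold lower number from compound 2 to compound 3 (0.05 log units; within the scatter) and so leaves these two groups indistinguishable at this place on the ring. Chloro in place of methyl gives a 2.2-fold higher number from compound 1 to compound 3 (0.34 log units; beyond the scatter) and so repeats the modest separation of methyl from methoxy, making methyl the only one of the three groups that stands apart. No measurement at hand accounts for this.

From the compounds shown here alone, whether an amine or a carboxylic acid on this aromatic carbon would shift the number remains open. So does whether these swaps would behave the same elsewhere on the shared core.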